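The source may report more compounds than this note shows. Statements on the series, on what has been measured and on what is new or still open speak of the compounds shown alone.

Among the compounds with values here, in a physicochemical assay for solubility, read by HPLC, measured as kinetic solubility, with a stated time of 24 h, at pH 6.5 (on this read-out higher numbers stand for higher solubility and lower numbers for lower solubility), compound 3 `CCNCc1cc(C)cc(Nc2nc3ccccc3n2Cc2ccc(C(F)(F)F)cc2)c1O` gives 35000 nM, the only true number among the measured compounds. Compound 1 `CC(C)(C)NCc1cc(Cl)cc(Nc2nc3cc(F)c(F)cc3n2Cc2ccc(C(F)(F)F)cc2)c1O` returns only a limit, < 5000 nM. Compound 2 `CC(C)(C)NCc1cc(Cl)cc(Nc2nc3ccccc3n2Cc2ccc(C(F)(F)F)cc2)c1O`, which carries chloro, also returns only a limit, < 5000 nM. Compound 4 `CCNCc1cc(Cl)cc(Nc2nc3ccccc3n2Cc2ccc(C(F)(F)F)cc2)c1O` keeps the (ethylamino)methyl group of compound 3 and has chloro in place of methyl on an aromatic carbon, para to a hydroxy group (chloro in place of methyl on an aromatic carbon). Within the data shown here, no measured step isolates this swap, so the limit of compound 2, < 5000 nM, is the only guide, and it points downward. A moderate fall in this assay, beyond the scatter, is expected, with an estimated 2.9-fold lower number from compound 3 to compound 4 (0.46 log units; beyond the scatter). For compound 4 the expected value is 12000 nM, with an estimated range of 5000 nM to 30000 nM.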

Compound 4, solubility: 12000 nM
Compound 4: the middle estimate sits on the measured number at the digits printed; measured number inside the range.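

In this assay, the spot para to a hydroxy group now has a direct comparison, as chloro in place of methyl gives a 2.9-fold lower number from compound 3 to compound 4 (0.46 log units; beyond the scatter). With chloro kept, ethyl in place of tert-butyl on the amine nitrogen gives an at least 2.4-fold higher number from compound 2 to compound 4 (0.38 log units; beyond the scatter), so the amine side also moves this read-out. That second step is open-ended, because compound 2 gives only a limit: the limit of < 5000 nM in this assay, at which 2 of the 4 values shown sit.

Steps between two limits cannot be read, so the effect of the two fluorines in compound 1 stays unknown. On these data alone, how a methoxy group or a nitrile would behave at the chloro spot also stays open.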